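This account rests on a few compounds, and the source may have more. Where it says the series, first, only, none or still open, it means among the compounds named here.

Working notes on the series. The shared core carries a urea-linked benzylamine with a chloro-substituted aryl amide, and the three measured compounds differ at the pyrrolidine-derived acyl end. Compound 1 `CO[C@@H]1C[C@@H](C(=O)N2CCC(N3CCCCC3)CC2)N(C(=O)NCc2ccc(C(=O)N3CCCCc4sccc43)cc2Cl)C1` gives 1200 nM in an assay on isolated protein with Vasopressin V2 receptor (Homo sapiens) as the target (a higher number here means that more compound is needed for the effect, a lower number that less compound is needed), the second highest of the three numbers recorded. Compound 2 `CN1CCCN(C(=S)[C@@H]2CCCN2C(=O)NCc2ccc(C(=O)N3CCCCc4sccc43)cc2Cl)CC1` gives 1800 nM in this assay, a number within the scatter of compound 1. Compound 3 `CO[C@@H]1C[C@@H](C(=S)N2CCC(N3CCCC3)CC2)N(C(=O)NCc2ccc(C(=O)N3CCCCc4sccc43)cc2Cl)C1` gives 100 nM in this assay, the lowest of the three and beyond the scatter from compound 1.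

Compound 4 `CO[C@@H]1C[C@@H](C(=O)N2CCCN(C)CC2)N(C(=O)NCc2ccc(C(=O)N3CCCCc4sccc43)cc2Cl)C1` has not been measured. It differs from compound 1 by 4-methyl-1,4-diazepan-1-yl in place of 4-(piperidin-1-yl)piperidin-1-yl on a carbonyl carbon. Among the measured compounds shown here, no measured pair isolates this exchange, so the expected size of the step rests on the values of compound 2 and compound 3 alone: the same seven-membered ring in compound 2 sits at the weaker end of the range, and the strongest number belongs to compound 3 with a thiocarbonyl. A step from compound 1 to compound 4 of a 2.1-fold higher number from compound 1 to compound 4 (0.32 log units; beyond the scatter) toward a higher number is expected, within or just beyond the scatter. Compound 4 is therefore estimated at 2500 nM in this assay, with a range from 800 nM to 8000 nM.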

Compound 4, half-maximal effective concentration: 1300 nM
For compound 4 the middle estimate is 1.9-fold (0.28 log units) above the measured one, within the range that was stated.
By their numbers in this assay, from the lowest: compound 3; then compounds 1, 4 and 2 (each within the scatter of the next).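

In this assay, among the compounds shown here, 4-methyl-1,4-diazepan-1-yl in place of 4-(piperidin-1-yl)piperidin-1-yl on a carbonyl carbon gives a 1.1-fold higher number from compound 1 to compound 4 (0.03 log units; within the scatter) as the only single-place step. At this position, therefore, two six-membered rings can give way to one seven-membered ring with fewer heavy atoms and no reading beyond the scatter. Nothing available explains why the two groups read alike.

Going by these compounds, whether the same tolerance extends to a smaller group on this carbonyl carbon, such as morpholin-4-yl or dimethylamino, or to a 4-methylpiperazin-1-yl ring, remains open. Also open, on these data alone, is what a thiocarbonyl in place of the carbonyl does on its own, since every compound carrying it also differs from compound 1 or compound 4 in a second place.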